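Imidazole substituent variation in a biphenyl-acid agonist series

This account rests on a few compounds, and the source may have more. Where it says the series, first, only, none or still open, it means among the compounds named here.

Measured compounds:
compound 1 `CCCCc1cnc(Cc2ccc(-c3ccccc3C(=O)O)cc2)[nH]1` — > 10000 nM
compound 2 `CCCCc1cnc(CCCc2ccc(-c3ccccc3C(=O)O)cc2)[nH]1` — 5600 nM
compound 3 `O=C(O)c1ccccc1-c1ccc(CCc2ncc(C3CCCCC3)[nH]2)cc1` — 375 nM

In an in vitro functional assay on cells for agonist activity at Bombesin receptor subtype-3 (Homo sapiens), read by luminescence and calcium flux (a lower number here means that less compound is needed, a higher number that more compound is needed for the effect), compound 3 gives 375 nM, the lowest of the two numbers available. Compound 2 gives 5600 nM in this assay, a gap from compound 3 that lies beyond the scatter. For compound 1 the assay reports only > 10000 nM; this is a limit, not a number, and it sits at the limit of > 10000 nM in this assay, at which 1 of the 3 values shown sits.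

Compound 4 `COc1cccc(Cc2cnc(CCc3ccc(-c4ccccc4C(=O)O)cc3)[nH]2)c1` has not yet been measured in this assay. It differs from compound 3 in one place: 3-methoxybenzyl in place of cyclohexyl on an aromatic carbon. Among the measured compounds shown here, no measured pair in the set shows a change of this kind, so no step can be read off directly; the only comparisons on hand concern the chain between the two ring systems, not the group on the imidazole carbon. A step of moderate size, in either direction, is expected, with the number for compound 4 estimated to fall near that of compound 3 rather than far from it. On that basis compound 4 is expected to give 500 nM in this assay, within a range of 100 nM to 3000 nM, which means an expected step of a 1.3-fold higher number from compound 3 to compound 4 (0.12 log units; within the scatter).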

Compound 4, half-maximal effective concentration: 4120 nM
Beside the measured number, compound 4's estimate is 8.2-fold (0.92 log units) below it; measured number above the stated range.
By their numbers in this assay, from the lowest: compound 3; then compounds 4 and 2 (each within the scatter of the next). At a limit, above all of these: compound 1.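

Among the compounds shown here, this is the first pair in the set that differs in one place, and it shows that the group on this aromatic carbon of the imidazole strongly affects the number in this assay: 3-methoxybenzyl in place of cyclohexyl gives an 11-fold higher number from compound 3 to compound 4 (1.04 log units; beyond the scatter). The change swaps a non-aromatic ring of carbon only for an aromatic one, adds a hydrogen-bond acceptor and enlarges the group, and this single step cannot separate these changes from one another. Nothing in the data at hand gives a reason for the step.

Open, on these data alone, is whether an unsubstituted benzyl or a phenyl on this carbon would give a number nearer that of compound 3 or that of compound 4. Also open, as far as these compounds go, is how a cyclopentyl or a tert-butyl on this carbon would compare with cyclohexyl.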